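Swapping the group on a double-bonded nitrogen

A few compounds are considered here, and "the series" means these few. Any claim that something is new, unique, unknown or untested is made for them only; others in the source may bear on it.

Measured in a functional assay on HCT-116 cells (Homo sapiens) for cytotoxicity, read by sulforhodamine B assay, with a stated time of 24 h; a lower number here means a stronger inhibitor, a higher number a weaker inhibitor
Compound 1 `N=c1oc2ccccc2cc1C(=O)N/N=C1\C(=O)Nc2ccc(S(=O)(=O)N3CCOCC3)cc21` gives 6750 nM
Compound 2 `Cc1ccc(/N=C2\C(=O)Nc3ccc(S(=O)(=O)N4CCOCC4)cc32)cc1` gives 18900 nM
Compound 3 `Cc1ccc(S(=O)(=O)N/N=C2\C(=O)Nc3ccc(S(=O)(=O)N4CCOCC4)cc32)cc1` gives 23400 nM

Compound 2 holds the second highest of these three numbers. Its gap to compound 3 lies within the scatter of repeated measurements, while compound 1 gives a lower number, beyond that scatter. Compound 4 `CC(=O)c1cccc(/N=C2\C(=O)Nc3ccc(S(=O)(=O)N4CCOCC4)cc32)c1` keeps the core of compound 2 and differs in one place (3-acetylphenyl in place of 4-methylphenyl on a double-bonded nitrogen), with 3-acetylphenyl in place of 4-methylphenyl on a double-bonded nitrogen. Within the data shown here, no measured pair here shows the effect of such a swap. The expectation therefore rests on compound 2 (18900 nM), and no change beyond the scatter is expected in this assay in either direction. The estimated step (a 1.2-fold lower number from compound 2 to compound 4 (0.07 log units; within the scatter)) lies within the scatter. The estimate for compound 4 is 16000 nM with 6500 nM to 38000 nM as its expected range.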

Compound 4, half-maximal inhibitory concentration: 29000 nM
Compound 4: the middle estimate sits 1.8-fold (0.26 log units) below what was measured; low and high end bracket the measured number.
By their numbers in this assay, from the lowest: compound 1; then compounds 2, 3 and 4 (each within the scatter of the next).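

Among these compounds, measured in this assay the swap of 4-methylphenyl for 3-acetylphenyl on a double-bonded nitrogen gives a 1.5-fold higher number from compound 2 to compound 4 (0.19 log units; within the scatter) and is the first single-place step read at this position. The entering group carries a hydrogen-bond acceptor that the leaving group lacks, yet the number stays within the scatter for this one change. No measurement here accounts for this result.

Going by these compounds, whether an amine or a carboxylic acid on this phenyl ring would move the number beyond the scatter remains open. The same holds for a longer chain in place of the ring.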